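This account rests on a few compounds, and the source may have more. Where it says the series, first, only, none or still open, it means among the compounds named here.

Compound 2 `Cc1ccccc1CN1CCC(CCNC(=O)/C=C/c2cc(C(C)(C)C)c(O)c(C(C)(C)C)c2)CC1` gives 7200 nM in an assay on isolated protein for inhibition of Amine oxidase [flavin-containing] B (Homo sapiens), read by fluorescence, with stated times of 15 min and 20 min (on this read-out higher numbers stand for weaker inhibition and lower numbers for stronger inhibition), and compound 1 `CC(C)(C)c1cc(/C=C/C(=O)NCCC2CCN(Cc3ccccc3)CC2)cc(C(C)(C)C)c1O` gives 8500 nM; the two values lie within the scatter of each other, as a 1.2-fold lower number from compound 1 to compound 2 (0.07 log units; within the scatter) shows. Compound 3 `Cc1ccc(CN2CCC(CCNC(=O)/C=C/c3cc(C(C)(C)C)c(O)c(C(C)(C)C)c3)CC2)cc1` differs from compound 2 by 4-methylphenyl in place of 2-methylphenyl on a saturated chain carbon bound to an amine nitrogen in a ring. Within the data shown here, the only measured step that bears on this change is the one from compound 1 to compound 2, which added the methyl and was within the scatter; moving it is therefore expected to give no step beyond the scatter, so a 1.0-fold lower number from compound 2 to compound 3 (0.01 log units; within the scatter) is estimated. Compound 3 is expected to give 7000 nM in this assay, within 3000 nM to 18000 nM.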

Compound 3, half-maximal inhibitory concentration: 8900 nM
The estimate for compound 3 lay 1.3-fold (0.10 log units) below the measured number; measured number inside the range.
By their numbers in this assay, from the lowest: compounds 2, 1 and 3 (each within the scatter of the next).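

In this assay, moving the methyl gives a 1.2-fold higher number from compound 2 to compound 3 (0.09 log units; within the scatter) and the 4-methylphenyl group in place of the plain phenyl gives a 1.0-fold higher number from compound 1 to compound 3 (0.02 log units; within the scatter) for the same ring. At this position on a saturated chain carbon bound to an amine nitrogen in a ring, neither methyl placement separates from the other or from hydrogen. No evidence bears on this result.

From the compounds shown here alone, it remains open whether 3-methylphenyl would behave the same way. Going by these compounds, it is also open whether a methoxy group or a carboxylic acid on this ring, in place of the methyl, would shift the number beyond the scatter.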